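From 4-methylphenylamino to piperidin-1-yl on the shared core

A few compounds are considered here, and "the series" means these few. Any claim that something is new, unique, unknown or untested is made for them only; others in the source may bear on it.

In a functional assay on HeLa cells (Homo sapiens) for inhibition, read by sulforhodamine B assay (a lower number here means a stronger inhibitor, a higher number a weaker inhibitor), compound 1 `O=C1C=C(NCc2ccccc2)C(=O)c2c1nc1n2[C@H]2OC[C@@H](O)[C@H]2OC1` reaches only a limit of the assay, > 8000 nM. Going by the values given here, compound 2 `Cc1ccc(NC2=CC(=O)c3nc4n(c3C2=O)[C@H]2OC[C@@H](O)[C@H]2OC4)cc1` gives 3860 nM, the only exact number so far. Compound 3 `O=C1C=C(N2CCCCC2)C(=O)c2c1nc1n2[C@H]2OC[C@@H](O)[C@H]2OC1` carries piperidin-1-yl in place of (4-methylphenyl)amino on a double-bonded ring carbon. Among the compounds with values here, the sole measured guide is an at least 2.0-fold lower number from compound 1 to compound 2 (0.31 log units; beyond the scatter), a modest gain with 4-methylphenyl in place of benzyl on an amine nitrogen. Losing that 4-methylphenyl, a modest rise toward weaker inhibition is expected, a 1.6-fold higher number from compound 2 to compound 3 (0.19 log units; within the scatter). For compound 3 the estimated value is 6000 nM, within a range of 2200 nM to 16000 nM.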

Compound 3, half-maximal inhibitory concentration: > 16000 nM
Compound 3: no number, only a limit; the forecaster's own chance of this, stated with the estimate: 40%; at least 2.6-fold (0.42 log units) between middle value and limit.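

On the double-bonded ring carbon, piperidin-1-yl in place of (4-methylphenyl)amino weakens inhibition in this assay, with an at least 4.1-fold higher number from compound 2 to compound 3 (0.61 log units; beyond the scatter). This shows that replacing the whole amine substituent matters at this position, as the earlier change of benzyl alone did. Compound 1 and compound 3 both stand only at limits of the assay, so the step between them cannot be read.

Compound 3 loses the aromatic ring and the hydrogen-bond donor together, and the compounds shown do not separate the two. Cyclohexylamino, which keeps the amine hydrogen on a non-aromatic ring, remains an open case.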